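Methyl shift on the isothiazole of compound 2

A few compounds are considered here, and "the series" means these few. Any claim that something is new, unique, unknown or untested is made for them only; others in the source may bear on it.

Measured so far:
compound 1 `c1ccc(-c2cnccn2)c(OCC2=NCCN2)c1`, 97%
compound 2 `Cc1cc(-c2ccccc2OCC2=NCCN2)sn1`, 75%

Among the measured compounds shown here, in a functional assay with Alpha-1A adrenergic receptor (Homo sapiens) as the target, read by calcium flux (on this read-out lower numbers stand for smaller maximal responses and higher numbers for larger maximal responses), compound 2 gives 75%, the lowest of the two numbers; the only measured step, a number 22 percentage points lower from compound 1 to compound 2 (beyond the scatter), lies beyond the scatter. Compound 3 `Cc1cnsc1-c1ccccc1OCC1=NCCN1` differs from compound 2 by 4-methyl-1,2-thiazol-5-yl in place of 3-methyl-1,2-thiazol-5-yl on an aromatic carbon. For the measured compounds named here, no measured step bears on this change; the step from compound 1 to compound 2 swaps one ring for another and says nothing about where the methyl sits. For compound 3 the expected step is no change at the digits printed from compound 2 to compound 3 (within the scatter), none beyond the scatter. Compound 3 is estimated at 75%, between 55% and 95%.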

Compound 3, largest response reached (reported as maximum), in percent of the reference or control that the assay uses: 104%
Beside the measured number, compound 3's estimate is 29 percentage points below it; the measured number lies above the stated range.
By their numbers in this assay, from the lowest: compound 2; then compounds 1 and 3 (each within the scatter of the next).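

In this assay, the place of the methyl alone moves the number: 4-methyl-1,2-thiazol-5-yl in place of 3-methyl-1,2-thiazol-5-yl gives a number 29 percentage points higher from compound 2 to compound 3 (beyond the scatter) with the same atoms joined differently. Against pyrazin-2-yl, 4-methyl-1,2-thiazol-5-yl gives a number 7 percentage points higher from compound 1 to compound 3 (within the scatter) so a methyl-bearing five-membered ring at this position does not by itself go with the lower number of compound 2. No measurement at hand explains the effect of the methyl shift. Open, on these data alone, is whether the methyl is needed at all, as the unsubstituted 1,2-thiazol-5-yl would show. Also open, as far as these compounds go, is how an ethyl or a methoxy in its place would read.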